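A Bromophenyl Swap on the More Potent Core

This account rests on a few compounds, and the source may have more. Where it says the series, first, only, none or still open, it means among the compounds named here.

Of the compounds shown here, three have been measured in a functional assay on HCT-116 cells (Homo sapiens) for antiproliferative activity, read by MTT assay, with a stated time of 72 h; a higher number here means a weaker inhibitor, a lower number a stronger inhibitor. Compound 1 `NC1=NC2(CCSCC2)N(OCCCOc2cc(Cl)c(Cl)cc2Cl)C(N)=N1` gives 1 nM. Compound 2 `NC1=NC2(CCOCC2)N(OCCCOc2cc(Cl)c(Cl)cc2Cl)C(N)=N1` and compound 3 `NC1=NC2(CCOCC2)N(OCCCOc2ccccc2Br)C(N)=N1` share a core that differs from the core of compound 1; the difference between the two cores is not broken down here. In this assay compound 2 gives 2750 nM, while compound 3 gives 30 nM. Compound 2 and compound 3 differ in one place: 2-bromophenyl in place of 2,4,5-trichlorophenyl on an oxygen on a saturated carbon That single change gave a 92-fold lower number from compound 2 to compound 3 (1.96 log units; beyond the scatter). Among the three, compound 1 has the lowest number, and both gaps to it lie beyond the scatter.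

Compound 4 `NC1=NC2(CCSCC2)N(OCCCOc2ccccc2Br)C(N)=N1` has not yet been measured. It carries the same change, now on the core of compound 1: 2-bromophenyl in place of 2,4,5-trichlorophenyl on an oxygen on a saturated carbon The place is the same in both pairs, so this is the same change, seen a second time.

The expectation for compound 4 rests on two things. The earlier step shows that this change can lower the number a great deal on the other core. Yet compound 1 already gives 1 nM, which leaves far less room for a drop of the same size, and nothing here shows how this change behaves on the more potent core. A much smaller step is therefore expected, roughly a 2.0-fold higher number from compound 1 to compound 4 (0.30 log units; within the scatter), with a wide range of uncertainty. Compound 4 is expected to give about 2 nM, most likely between 0.3 nM and 20 nM.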

Compound 4, half-maximal inhibitory concentration: 1 nM
Compound 4: the middle estimate sits 2.0-fold (0.30 log units) above what was measured, and the stated range covers the measured number.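

Placed on the more potent core, the swap of 2,4,5-trichlorophenyl for 2-bromophenyl gives no change at the digits printed from compound 1 to compound 4 (within the scatter) in this assay. The large gain seen on the other core therefore does not reappear here, so in this series the size of this step cannot simply be carried from one core to the other: the same change on two cores in this assay, a 92-fold lower number (1.96 log units; beyond the scatter) from compound 2 to compound 3 and no change at the digits printed (within the scatter) from compound 1 to compound 4, 92-fold (1.96 log units) apart, beyond the scatter of two such steps

This comparison shows that the core matters to what the change does, but it does not show why the two steps part, and two cores are too few to support a rule for any further core.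

The compounds shown leave open how the same swap would behave on a third core, and whether the phenyl ring needs a halogen at all, since a plain phenyl group or a phenyl ring carrying an amine or a carboxylic acid does not appear among them. They also leave open what a longer chain would do in place of the present saturated chain that links the oxygen atoms, on either core.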